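Ethyl for fluoro on the anilide ring of compound 1

This account rests on a few compounds, and the source may have more. Where it says the series, first, only, none or still open, it means among the compounds named here.

Going by the values given here, compound 1 `O=C(Nc1cccc(F)c1)c1cncc(N2CC3CC(C2)N3)c1` is one of three compounds measured in an assay on cells for displacement of a labelled ligand from Neuronal acetylcholine receptor; alpha3/beta4 (Homo sapiens); a higher number here means a weaker inhibitor, a lower number a stronger inhibitor. In this assay compound 1 gives 28 nM, the second highest of the three numbers. Compound 2 `O=C(c1cncc(N2CC3CC(C2)N3)c1)N1CCc2ccccc2C1` gives 21 nM, a number within the scatter of that of compound 1. Among the compounds with values here, compound 3 `O=C(Nc1ccc(F)cc1)c1cncc(N2CC3CC(C2)N3)c1` gives 81 nM, and the single one-place step, a 2.9-fold higher number from compound 1 to compound 3 (0.46 log units; beyond the scatter), shows that 4-fluorophenyl in place of 3-fluorophenyl on the amide-type nitrogen carries a modest cost.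

Compound 4 `CCc1cccc(NC(=O)c2cncc(N3CC4CC(C3)N4)c2)c1` is not yet measured. It differs from compound 1 in one place: ethyl in place of fluoro on an aromatic carbon, so that 3-fluorophenyl becomes 3-ethylphenyl. Within the data shown here, no measured step exchanges the fluoro for another group at this position; the step from compound 1 to compound 3 concerns where the fluoro sits, not what stands there, so it bears on the change only indirectly, by showing that the anilide ring tolerates a change of this order with a modest shift. The account therefore expects compound 4 to stay near compound 1, with a step of a 1.4-fold higher number from compound 1 to compound 4 (0.15 log units; within the scatter) in this assay, and estimates for compound 4 a value of 40 nM, within a range from 12 nM to 130 nM.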

Compound 4, inhibition constant: 306 nM
For compound 4 the middle estimate is 7.7-fold (0.88 log units) below the measured one, outside the stated range (above it).
By their numbers in this assay, from the lowest: compounds 2 and 1 (each within the scatter of the next); then compound 3; then compound 4.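

In this assay, going by these compounds alone, the exchange of fluoro for ethyl on this aromatic carbon gives an 11-fold higher number from compound 1 to compound 4 (1.04 log units; beyond the scatter) and so counts as a large step, whereas the only earlier step on this ring, which moved the fluoro, was modest. What stands on the ring therefore matters more than compound 1 and compound 3 could show, and the anilide ring does not tolerate every change of this order. The 3-ethylphenyl group also compares poorly with the 4-fluorophenyl group, with a 3.8-fold higher number from compound 3 to compound 4 (0.58 log units; beyond the scatter) in this assay, so among these three anilides the ethyl carries the highest number, though nothing given here says why the step is so large.

The compounds shown leave open whether the loss belongs to ethyl alone or would also follow from a methyl, a chloro or a methoxy group on the same carbon, since fluoro and ethyl are the only two groups compared there. They also leave open how ethyl would behave as a 4-ethylphenyl group, and whether a hydroxyl or an amine on the ethyl chain would change the number.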